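An Isobutyl Amide Awaits Its Cytotoxicity Reading

A few compounds are considered here, and "the series" means these few. Any claim that something is new, unique, unknown or untested is made for them only; others in the source may bear on it.

Compound 1 `C=CC1=C(C(=O)O)C(c2ccc(F)cc2)OC1`: > 100000 nM
Compound 2 `C=CC1=C(C(=O)O)C(c2ccc(OC)cc2)OC1`: > 100000 nM
Compound 3 `C=CC1=C(C(=O)NC(C)(C)C)C(c2ccc(OC)cc2)OC1`: > 100000 nM

In a functional assay on SW480 cells (Homo sapiens) for cytotoxicity, read by MTT assay, with a stated time of 24 h (on this read-out lower numbers stand for stronger inhibition and higher numbers for weaker inhibition), compound 1 gives only a limit of the assay, > 100000 nM. Compound 2 likewise returns a limit, > 100000 nM. Compound 3 also stops at a limit, > 100000 nM. Hence (the limit of > 100000 nM in this assay, at which 3 of the 3 values shown sit), and both a step that the two limits leave unreadable from compound 1 to compound 2 and a step that the two limits leave unreadable from compound 2 to compound 3 remain unreadable in size. Compound 4 `C=CC1=C(C(=O)NCC(C)C)C(c2ccc(F)cc2)OC1` differs from compound 1 by isobutylamino in place of hydroxy on a carbonyl carbon. The closest measured comparison, the amide step from compound 2 to compound 3, cannot be read, so compound 4 is expected to show a step that the limit leaves unreadable from compound 1 to compound 4, most probably ending at the same limit. For compound 4 the estimate is 150000 nM, ranging from 40000 nM to 600000 nM.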

Compound 4, half-maximal inhibitory concentration: > 100000 nM
Compound 4 was reported as a limit (the forecaster's own chance of this, stated with the estimate: 80%); the middle value is on the limit's open side.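

In this assay compound 4 gives > 100000 nM, a limit, so the step to it from compound 1 cannot be read. The compounds shown leave open what activity, if any, lies beyond that limit: the limit of > 100000 nM in this assay, at which 4 of the 4 values shown sit.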